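Trifluoromethyl for Dichloro on the Urea Aryl

The source may report more compounds than this note shows. Statements on the series, on what has been measured and on what is new or still open speak of the compounds shown alone.

Among the compounds with values here, compound 2 `COc1cc(Cl)cc(-c2nn(-c3cccc(NC(=O)Nc4ccc(Cl)c(Cl)c4)c3)cc2-c2ccncc2)c1` gives 96% in a functional assay on A498 cells (Homo sapiens) for inhibition, read by sulforhodamine B assay, with a stated time of 48 h, tested at 0.01 uM (on this read-out higher numbers stand for a weaker effect at the one concentration tested and lower numbers for a stronger effect), the higher of the two numbers measured so far. Compound 1 `COc1cc(Cl)cc(-c2nn(-c3cccc(NC(=O)Nc4ccc(Cl)c(C(F)(F)F)c4)c3)cc2-c2ccncc2)c1` gives 57% in this assay. Within the data shown here, the only measured step, a number 39 percentage points higher from compound 1 to compound 2 (beyond the scatter), was large. Compound 3 `COc1cc(Cl)cc(-c2nn(-c3cccc(NC(=O)Nc4cccc(C(F)(F)F)c4)c3)cc2-c2ccncc2)c1` differs from compound 2 by 3-(trifluoromethyl)phenyl in place of 3,4-dichlorophenyl on an amide-type nitrogen. This change bears on that earlier step: trifluoromethyl returns, though one chloro is also lost, so compound 3 is not simply compound 1. Among the measured compounds shown here, no measured compound shows the loss of that chloro on its own. Because compound 1 gave 57% with trifluoromethyl present, the step of a number 24 percentage points lower from compound 2 to compound 3 (beyond the scatter) is expected to run downward, with less certainty than the measured step. Compound 3 is therefore estimated at 72% in this assay, with a range from 50% to 95%.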

Compound 3, a percentage reported as activity, at one concentration (the size of the read-out at that concentration, not a potency): 95%
Beside the measured number, compound 3's estimate is 23 percentage points below it; the range from low to high includes it.
By their numbers in this assay, from the lowest: compound 1; then compounds 3 and 2 (each within the scatter of the next).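

In this assay, within the data shown here, the step of a number 38 percentage points higher from compound 1 to compound 3 (beyond the scatter) isolates the chloro on the aromatic carbon, which the earlier compounds could not do. With trifluoromethyl kept, the lower number of compound 1 does not survive the replacement of that chloro by hydrogen, so trifluoromethyl alone does not carry it. The step of a number 1 percentage points lower from compound 2 to compound 3 (within the scatter) shows that 3-(trifluoromethyl)phenyl and 3,4-dichlorophenyl on the amide-type nitrogen cannot be told apart here, and nothing available explains why the two groups are needed together.

As far as these compounds go, it remains open whether that chloro is specifically required, or whether a fluoro, methyl or methoxy group in its place, with trifluoromethyl kept, would match compound 1. From the compounds shown here alone, it is also open whether the same combination would hold with a nitrile or an amine in place of trifluoromethyl.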